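Adding an Aromatic Ring to Compound 3

A few compounds are considered here, and "the series" means these few. Any claim that something is new, unique, unknown or untested is made for them only; others in the source may bear on it.

In a functional assay on HeLa cells (Homo sapiens) for inhibition, read by MTT assay, with a stated time of 48 h (on this read-out lower numbers stand for stronger inhibition and higher numbers for weaker inhibition), compound 1 `CCOC(=O)C1=C(N/C=N/c2cccnc2Cl)Nc2[nH]nc(C)c2C1c1ccc(N(C)C)cc1` gives 4630 nM, compound 2 `CCOC(=O)C1=C(N/C=N/c2nnc(S(N)(=O)=O)s2)Nc2[nH]nc(C)c2C1c1ccc(N(C)C)cc1` gives 26300 nM and compound 3 `CCOC(=O)C1=C(N/N=C(\C#N)C(N)=O)Nc2[nH]nc(C)c2C1c1ccc(N(C)C)cc1` gives 47300 nM. Compound 3 therefore stands clearly apart from only one of the others: the data show a 10-fold higher number from compound 1 to compound 3 (1.01 log units; beyond the scatter), whereas a 1.8-fold higher number from compound 2 to compound 3 (0.25 log units; within the scatter) is no real difference.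

Compound 4 `CCOC(=O)C1=C(N/N=C(/C(=O)Br)c2ccc(Br)cc2)Nc2[nH]nc(C)c2C1c1ccc(N(C)C)cc1` keeps the shared core but differs from compound 3 by a group of 12 heavy atoms (8 carbon, 1 nitrogen, 1 oxygen, 2 bromine; one six-membered aromatic ring of carbon only) in place of a group of 7 heavy atoms (3 carbon, 3 nitrogen, 1 oxygen; no ring), on an amine nitrogen. Its new six-membered aromatic ring makes compound 1, which also carries such a ring, the nearest guide, and that compound's a 10-fold higher number from compound 1 to compound 3 (1.01 log units; beyond the scatter) points towards a lower number. The guide is imperfect, as the ring of compound 1 holds a hetero atom. Compound 2 also goes against a simple rule that a ring lowers the number, since it has a five-membered aromatic ring and the data show a 5.7-fold higher number from compound 1 to compound 2 (0.75 log units; beyond the scatter).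

A modest move to a lower number in this assay is therefore expected, smaller than the full gap to compound 1. The estimated change is a 3.0-fold lower number from compound 3 to compound 4 (0.47 log units; beyond the scatter). For compound 4, the expected value is 16000 nM, within an estimated range of 4500 nM to 50000 nM.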

Compound 4, half-maximal inhibitory concentration: 68500 nM
Beside the measured number, compound 4's estimate is 4.3-fold (0.63 log units) below it, outside the stated range (above it).
By their numbers in this assay, from the lowest: compound 1; then compounds 2, 3 and 4 (each within the scatter of the next, the first and the last beyond it).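

On the amine nitrogen, bringing in a six-membered aromatic ring of carbon only, within a group that also holds two bromine atoms, does not move the result in this assay: the data show a 1.4-fold higher number from compound 3 to compound 4 (0.16 log units; within the scatter), so a group with this ring and the ring-free group read alike. An aromatic ring alone therefore does not bring a compound close to compound 1, as a 15-fold higher number from compound 1 to compound 4 (1.17 log units; beyond the scatter) makes plain, and the new group also separates from the five-membered ring of compound 2, with a 2.6-fold higher number from compound 2 to compound 4 (0.42 log units; beyond the scatter) as the step. No measurement given here accounts for these differences.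

The compounds shown leave open whether the ring or the bromine atoms set this value. A plain phenyl group without bromine, or a phenyl group carrying a methoxy group, would help to separate the two.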